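This account rests on a few compounds, and the source may have more. Where it says the series, first, only, none or still open, it means among the compounds named here.

Compound 3 `CCC(CC)Cn1c(Cc2cc(OC)c(OC)c(OC)c2)nc2c(N)ncnc21` gives the highest number of the three in a functional assay on MCF7 cells (Homo sapiens) for antiproliferative activity (on this read-out lower numbers stand for stronger inhibition and higher numbers for weaker inhibition), namely 158000 nM. Compound 1 `COc1cc(Cc2nc3c(N)ncnc3n2CC2CCCCC2)cc(OC)c1OC` gives 39800 nM and compound 2 `C#CCCCn1c(Cc2cc(OC)c(OC)c(OC)c2)nc2c(N)ncnc21` gives 24000 nM. The steps of a 4.0-fold higher number from compound 1 to compound 3 (0.60 log units; beyond the scatter) and a 6.6-fold higher number from compound 2 to compound 3 (0.82 log units; beyond the scatter) both go with the pentan-3-yl group of compound 3 and both point toward weaker inhibition. Compound 4 `COc1cc(Cc2nc3c(N)ncnc3n2CC2(C)CC2)cc(OC)c1OC` carries the change (1-methylcyclopropyl in place of pentan-3-yl on a saturated chain carbon bound to an aromatic nitrogen). The two measured steps bear on it, since each exchanges the pentan-3-yl group against another group on the same carbon, and both were modest. Removing that group is therefore expected to give a modest step toward stronger inhibition, a 3.2-fold lower number from compound 3 to compound 4 (0.50 log units; beyond the scatter). For compound 4 the estimate is 50000 nM, with a range from 15000 nM to 160000 nM.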

Compound 4, half-maximal inhibitory concentration: 112000 nM
Beside the measured number, compound 4's estimate is 2.2-fold (0.35 log units) below it, within the range that was stated.
By their numbers in this assay, from the lowest: compounds 2 and 1 (each within the scatter of the next); then compounds 4 and 3 (each within the scatter of the next).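

In this assay there is a 1.4-fold lower number from compound 3 to compound 4 (0.15 log units; within the scatter) when 1-methylcyclopropyl replaces pentan-3-yl, so the small ring does not set compound 4 apart from compound 3. On the same carbon there is also a 2.8-fold higher number from compound 1 to compound 4 (0.45 log units; beyond the scatter) and a 4.7-fold higher number from compound 2 to compound 4 (0.67 log units; beyond the scatter) here, so carrying a ring at this place does not by itself give the numbers of compound 1 or compound 2. Nothing measured here explains these differences. On these data alone, whether an amine, a carboxylic acid or a longer chain on this carbon would give lower numbers stays open.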